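One Fluorine Added to a Weakly Cytotoxic Compound

A few compounds are considered here, and "the series" means these few. Any claim that something is new, unique, unknown or untested is made for them only; others in the source may bear on it.

So far, three compounds have been measured in a functional assay on MIA PaCa-2 cells (Homo sapiens) for cytotoxicity, read by WST assay, with a stated time of 48 h (a lower number here means a stronger inhibitor, a higher number a weaker inhibitor), and a fourth awaits measurement. Compound 3 `COc1ccc2c(/C=C(\C#N)C(=O)c3c[nH]c4ccccc34)c[nH]c2c1` reaches only a limit of the assay, > 50000 nM. Compound 1 `COc1ccc2c(/C=C(\C#N)C(=O)c3c[nH]c4cc(F)ccc34)c[nH]c2c1` likewise gives only a limit, > 50000 nM. The change from compound 3 to compound 1 is fluoro in place of hydrogen on an aromatic carbon, and the step it made, a step that the two limits leave unreadable from compound 3 to compound 1, cannot be read because of the limit of > 50000 nM in this assay, at which 2 of the 3 values shown sit. Compound 2 `COc1ccc2[nH]cc(/C=C(\C#N)C(=O)c3c[nH]c4ccccc34)c2c1` is built from the same atoms as compound 3, joined differently; the difference between the two cores is not broken down here. In this assay, going by the values given here, compound 2 gives 25100 nM, the only number among the three measured values.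

Compound 4 `COc1ccc2[nH]cc(/C=C(\C#N)C(=O)c3c[nH]c4cc(F)ccc34)c2c1` carries the same change already seen from compound 3 to compound 1, now made on compound 2: fluoro in place of hydrogen on an aromatic carbon. Since the earlier step stands unreadable, analogy gives no size for the new one. Among the compounds with values here, the value of compound 2 is the only number available, and on it rests the expectation that the step stays small, a 1.2-fold higher number from compound 2 to compound 4 (0.08 log units; within the scatter). For compound 4 the estimated value in this assay is 30000 nM, expected to lie between 12000 nM and 75000 nM, with a real chance that the assay again reports only a limit.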

Compound 4, half-maximal inhibitory concentration: > 50000 nM
Compound 4: no number, only a limit (the forecaster's own chance of this, stated with the estimate: 35%); middle value at least 1.6-fold (0.22 log units) from the limit.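

In this assay, fluoro in place of hydrogen on an aromatic carbon gives an at least 1.9-fold higher number from compound 2 to compound 4 (0.29 log units; that floor lies within the scatter), a floor and not a measured size. Compound 4 gives > 50000 nM, which is a limit of the assay and not a number, so the true step could be small or much larger, and the floor alone does not establish a real loss of activity. The same change on the other core, from compound 3 to compound 1, cannot be read, so these compounds do not show whether the change acts alike on both cores, and the two steps cannot be compared because the values stop at one limit: the limit of > 50000 nM in this assay, at which 3 of the 4 values shown sit.

The compounds shown leave open what a chloro group, an amine or a carboxylic acid would do on the same aromatic carbon, since only hydrogen and fluoro appear there. Such a step would have a readable size only if both compounds gave numbers, and so far only compound 2 does, with 25100 nM.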